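Urea-linked hydrazones on a shared core: pyrrole replaces bromophenol

This account rests on a few compounds, and the source may have more. Where it says the series, first, only, none or still open, it means among the compounds named here.

Measured compounds:
Compound 1 `O=C(N/N=C/c1ccc(O)cc1)Nc1ccc(Oc2ccnc3[nH]ccc23)cc1` — 32200 nM
Compound 2 `O=C(N/N=C/c1ccc(O)cc1Br)Nc1ccc(Oc2ccnc3[nH]ccc23)cc1` — "not determined" (no result reported)

Compound 1 `O=C(N/N=C/c1ccc(O)cc1)Nc1ccc(Oc2ccnc3[nH]ccc23)cc1` was tested in a functional assay on HepG2 cells (Homo sapiens) for antiproliferative activity, read by MTT assay, with a stated time of 72 h (a higher number here means a weaker inhibitor, a lower number a stronger inhibitor), where compound 1 gives 32200 nM. Compound 2 `O=C(N/N=C/c1ccc(O)cc1Br)Nc1ccc(Oc2ccnc3[nH]ccc23)cc1` shares the same core; in this assay compound 2 has "not determined" (no result reported), so no single number places it on the scale. Compound 3 `CN(C)CCn1cccc1/C=N/NC(=O)Nc1ccc(Oc2ccnc3[nH]ccc23)cc1` has not been measured. Compared with compound 2, the change is 1-(2-(dimethylamino)ethyl)-1H-pyrrol-2-yl in place of 2-bromo-4-hydroxyphenyl on a carbon with a double bond to nitrogen. Within the data shown here, no measured pair shows this kind of replacement, so the size of the step in this assay cannot be read from the data; only compound 1 sets a reference point, and it is a weak inhibitor. The account therefore expects compound 3 to stay in the weak range, with no step beyond the scatter that can be claimed in either direction. Compound 3 is estimated at 15000 nM, within 3000 nM to 60000 nM.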

Compound 3, half-maximal inhibitory concentration: "not active" (no number reported)
For compound 3 the study gives words and no number; no gap can be computed for the estimate.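

No new step can be read: neither compound 2 nor compound 3 has a number in this assay to compare. Nothing given here bears on this result. The compounds shown leave open how far the pyrrole replacement in compound 3 shifts antiproliferative activity.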